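A few compounds are considered here, and "the series" means these few. Any claim that something is new, unique, unknown or untested is made for them only; others in the source may bear on it.

Measured compounds:
- compound 1, `COc1ccc(C(=O)N(O)C(C)c2ccc3oc(-c4ccccc4)cc3c2)cc1OC`: 200 nM
- compound 2, `CCOC(=O)CCC(=O)N(O)C(C)c1ccc2oc(-c3ccccc3)cc2c1`: 50 nM
- compound 3, `COC(=O)CCCC(=O)N(O)C(C)c1ccc2oc(-c3ccccc3)cc2c1`: 60 nM

All three share one core and differ only in the acyl group on the hydroxamate nitrogen. In an assay on RBL cells for inhibition of Polyunsaturated fatty acid 5-lipoxygenase (Rattus norvegicus) (on this read-out lower numbers stand for stronger inhibition and higher numbers for weaker inhibition), compound 3 has the second highest of the three numbers. Its nearest neighbour is compound 2, and the pair shows a 1.2-fold higher number from compound 2 to compound 3 (0.08 log units; within the scatter). The distance to compound 1 is larger: a 3.3-fold lower number from compound 1 to compound 3 (0.52 log units; beyond the scatter), and a 4.0-fold lower number from compound 1 to compound 2 (0.60 log units; beyond the scatter).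

Compound 4, `CCCCc1cc2cc(C(C)N(O)C(=O)CCCC(=O)OC)ccc2o1`, is the next point. It keeps the methoxycarbonyl-propyl acyl group of compound 3 and changes the core instead: butyl in place of phenyl on an aromatic carbon. For the measured compounds named here, none of the measured steps touches this position; every step so far runs between acyl groups on the carbonyl carbon, so there is no direct precedent for swapping the aryl substituent on the five-membered ring for a chain. As far as these compounds go, with the acyl side held constant, the working expectation is a step of a 1.2-fold higher number from compound 3 to compound 4 (0.07 log units; within the scatter) in this assay, that is, no change beyond the scatter, with a wide margin in both directions since the position is untested. Compound 4 is therefore expected to give 70 nM in this assay, within a range of 20 nM to 250 nM.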

Compound 4, half-maximal inhibitory concentration: 50 nM
Beside the measured number, compound 4's estimate is 1.4-fold (0.15 log units) above it; the range from low to high includes it.
By their numbers in this assay, from the lowest: compounds 2, 4 and 3 (each within the scatter of the next); then compound 1.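

The aromatic carbon next to the ring oxygen now has a step of its own: in this assay, butyl in place of phenyl gives a 1.2-fold lower number from compound 3 to compound 4 (0.08 log units; within the scatter), so the change stays within the scatter. With the 3-(methoxycarbonyl)propyl acyl group held constant, this pair shows that a six-membered aromatic ring at this place can give way to a chain with no ring and fewer heavy atoms without a change in the read-out beyond the scatter. No measurement in hand explains why phenyl and butyl read alike here.

As far as these compounds go, this rests on a single pair, so it remains open whether butyl would read the same way alongside another acyl group, such as the 3,4-dimethoxyphenyl of compound 1 or the 2-(ethoxycarbonyl)ethyl of compound 2. From the compounds shown here alone, it also remains open how far this place tolerates other groups, for example a longer chain such as octyl, a chain ending in a carboxylic acid or an amine, or a bare hydrogen in place of butyl.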